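Benzylamino for benzyloxy at the assay limit

This account rests on a few compounds, and the source may have more. Where it says the series, first, only, none or still open, it means among the compounds named here.

Compound 2 `Nc1nc(OCc2ccccc2)c2ncn(/C=C3/CC3(CO)CO)c2n1` reads > 300000 nM in an ADME assay on HFF cells (Homo sapiens) for cytotoxicity, with a stated time of 8 days (a higher number here means that more compound is tolerated, a lower number that less compound is tolerated), as its only entry, a limit and not a number. Compound 1 `CNc1nc(N)nc2c1ncn2/C=C1/CC1(CO)CO` gives 265000 nM as a measured number. Compound 3 `Nc1nc(NCc2ccccc2)c2ncn(/C=C3/CC3(CO)CO)c2n1` differs from compound 2 by benzylamino in place of benzyloxy on an aromatic carbon with benzylamino in place of benzyloxy on an aromatic carbon. Going by an at least 1.1-fold higher number from compound 1 to compound 2 (0.05 log units; that floor lies within the scatter) as the one measured step, with benzyloxy in place of methylamino on an aromatic carbon, no change beyond the scatter is expected in this assay for this swap. The estimated step is an at least 1.2-fold lower number from compound 2 to compound 3 (0.07 log units; that floor lies within the scatter) on these grounds. For compound 3 the expected value is 250000 nM with an estimated range from 100000 nM to 400000 nM in this series.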

Compound 3, half-maximal cytotoxic concentration: > 300000 nM
Compound 3 was reported as a limit; the forecaster's own chance of this, stated with the estimate: 50%; at least 1.2-fold (0.07 log units) between middle value and limit.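

In this assay compound 3, with benzylamino on this aromatic carbon, gives > 300000 nM, a limit and not a number. Phenyl in place of hydrogen on a saturated chain carbon bound to a nitrogen on an aromatic ring gives an at least 1.1-fold higher number from compound 1 to compound 3 (0.05 log units; that floor lies within the scatter), so only a floor is known for this change. The swap of benzyloxy for benzylamino cannot be read: the limit of > 300000 nM in this assay, at which 2 of the 3 values shown sit.

Open, going by these compounds, is the true size of both changes. Also open, on these data alone, is whether a carboxylic acid or a longer chain on this carbon would give a measured number.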